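A few compounds are considered here, and "the series" means these few. Any claim that something is new, unique, unknown or untested is made for them only; others in the source may bear on it.

Working notes on the series. All compounds share one core and differ at the amine nitrogen in the ring. Compound 1 `NC(=O)c1c(NC(=O)Nc2ccc(Cl)cc2)sc2c1CCN(C1CCOCC1)C2` gives in a functional assay (strain AB) with Danio rerio as the target, read by microscopy, with a stated time of 1 h (on this read-out higher numbers stand for an effect only at larger amounts of compound and lower numbers for an effect already at smaller amounts), a value of 2830 nM, the highest of the three numbers obtained so far. Compound 2 `C[N+]1(CC2CCC2)CCc2c(sc(NC(=O)Nc3ccc(Cl)cc3)c2C(N)=O)C1` gives 210 nM in this assay, and compound 3 `C[N+]1(CC2CCCC2)CCc2c(sc(NC(=O)Nc3ccc(Cl)cc3)c2C(N)=O)C1` gives 200 nM; both numbers lie beyond the scatter from that of compound 1, but each of these compounds differs from compound 1 in more than one place, so the gap is not a single step. Going by the values given here, the only single-place step available is a 1.1-fold lower number from compound 2 to compound 3 (0.02 log units; within the scatter).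

Compound 4 `CC(C)(C)OC(=O)CCN1CCc2c(sc(NC(=O)Nc3ccc(Cl)cc3)c2C(N)=O)C1` is not yet measured. It differs from compound 1 as follows: 2-(tert-butoxycarbonyl)ethyl in place of oxan-4-yl on an amine nitrogen in a ring. Among the compounds with values here, no measured step covers this kind of exchange; the step from cyclobutyl to cyclopentyl between compound 2 and compound 3 alters a ring on a chain carbon and bears only loosely on it, and its size is within the scatter. The values of compound 2 and compound 3 show that other groups at this nitrogen can go with clearly lower numbers than compound 1, but those compounds carry further changes. The expectation for compound 4 is therefore a number near that of compound 1, with wide uncertainty. Compound 4 is estimated at 1500 nM, range 400 nM to 6000 nM, an expected step of a 1.9-fold lower number from compound 1 to compound 4 (0.28 log units; within the scatter).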

Compound 4, half-maximal effective concentration: 1100 nM
For compound 4 the middle estimate is 1.4-fold (0.13 log units) above the measured one; the measured number falls inside the stated range.
By their numbers in this assay, from the lowest: compounds 3 and 2 (each within the scatter of the next); then compound 4; then compound 1.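

In this assay, going by these compounds alone, the exchange of oxan-4-yl for 2-(tert-butoxycarbonyl)ethyl on an amine nitrogen in a ring gives a 2.6-fold lower number from compound 1 to compound 4 (0.41 log units; beyond the scatter) and is the first single-place step at this nitrogen to lie beyond the scatter, although it is modest in size. The position therefore takes an open chain with no ring, more heavy atoms and one more hydrogen-bond acceptor in place of the six-membered ring without a rise in the number, whereas the earlier exchange of cyclobutyl for cyclopentyl, a 1.1-fold lower number from compound 2 to compound 3 (0.02 log units; within the scatter), showed no change that could be told from the scatter. Nothing at hand gives a measured reason for the step from oxan-4-yl to this chain.

Within the data shown here, the single step does not separate the loss of the ring from the gain of the tert-butyl ester end, and a carboxylic acid at the end of the same chain or a plain propyl chain on this nitrogen would bear on that question. Also open, from the compounds shown here alone, is what a cyclobutylmethyl group on this nitrogen, without the methyl carried by compound 2, would give on this read-out.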